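The source may report more compounds than this note shows. Statements on the series, on what has been measured and on what is new or still open speak of the compounds shown alone.

Measured compounds:
- compound 1, `CCOC(=O)C(=O)Nc1nc(-c2cc(OC)cc(OC)c2)cs1`: about 10 mg/kg
- compound 2, `COc1cc(OC)cc(-c2csc(NC(=O)C(=O)O)n2)c1`: about 1 mg/kg
- compound 3, `CCOC(=O)C(=O)Nc1nc(-c2ccc(-c3ccccc3)cc2O)cs1`: > 10 mg/kg

Of the compounds shown here, three have been tested in a functional assay on the whole organism with Rattus norvegicus as the target; on this read-out higher numbers stand for an effect only at larger amounts of compound and lower numbers for an effect already at smaller amounts. Compound 1 (`CCOC(=O)C(=O)Nc1nc(-c2cc(OC)cc(OC)c2)cs1`) gives about 10 mg/kg. Compound 2 (`COc1cc(OC)cc(-c2csc(NC(=O)C(=O)O)n2)c1`) gives about 1 mg/kg. Compound 3 (`CCOC(=O)C(=O)Nc1nc(-c2ccc(-c3ccccc3)cc2O)cs1`) gives > 10 mg/kg, which is a limit of the assay and not a number, so for compound 3 only a range is known (the limit of > 10 mg/kg in this assay, at which 1 of the 3 values shown sits).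

Compound 1 and compound 2 differ in one place only: hydrogen in place of ethyl on an oxygen next to a carbonyl group. That change produced a 10-fold lower number from compound 1 to compound 2 (1.00 log units; beyond the scatter), a step clearly beyond the usual scatter of this kind of measurement.

Compound 4 (`O=C(O)C(=O)Nc1nc(-c2ccc(-c3ccccc3)cc2O)cs1`) has not yet been measured. It differs from compound 3 in exactly the same way: hydrogen in place of ethyl on an oxygen next to a carbonyl group. The change is the same, since the place where it sits is described in the same words for both pairs. The cores of compound 1 and compound 3, however, are not the same, and the difference between the two cores is not broken down here.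

The expectation for compound 4 rests on the step seen from compound 1 to compound 2, a 10-fold lower number from compound 1 to compound 2 (1.00 log units; beyond the scatter), carried over to the new core. Because compound 3 gives only the limit > 10 mg/kg, the starting point is uncertain, and the expected step from compound 3 to compound 4 is set at an at least 3.3-fold lower number from compound 3 to compound 4 (0.52 log units; beyond the scatter). On that basis compound 4 is expected to give about 3 mg/kg in this assay, with a likely range from 1 mg/kg to 30 mg/kg.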

Compound 4, dose for half-maximal effect: > 30 mg/kg
Compound 4: no number, only a limit (the forecaster's own chance of this, stated with the estimate: 30%); at least 10-fold (1.00 log units) between middle value and limit.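

In this assay, compound 3 and compound 4 each give a limit and not a number, so no step can be read between them. The compounds shown leave open whether hydrogen in place of ethyl on an oxygen next to a carbonyl group, the change that gave a 10-fold lower number from compound 1 to compound 2 (1.00 log units; beyond the scatter), shifts the read-out at all on the core of compound 3.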